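A few compounds are considered here, and "the series" means these few. Any claim that something is new, unique, unknown or untested is made for them only; others in the source may bear on it.

Measured so far:
- compound 1 `CCCCCCCCN(C)C(=O)Cn1cc(Cc2cnc(=O)n(CC(=O)NC)c2)c(=O)nc1SCc1ccc(F)cc1`: 63%
- compound 2 `CCCCCCCCN(C)C(=O)Cn1cc(Cc2cnc(=O)n(CC(=O)N3CCOCC3)c2)c(=O)nc1SCc1ccc(F)cc1`: 64%

In a functional assay on a cell-free system (plasma) for inhibition of platelet-activating factor acetylhydrolase (Homo sapiens), tested at 100 nM (a higher number here means more inhibition at the concentration tested (going by the name of the read-out), a lower number less inhibition), compound 1 gives 63%, and compound 2 gives 64%. Of the two readings compound 2 carries the nominally larger one, but the step of a number 1 percentage points higher from compound 1 to compound 2 (within the scatter) is within the scatter, so the two compounds cannot be told apart on these numbers.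

Compound 3 `CCCCCCCCN(C)C(=O)Cn1cc(Cc2cnc(=O)n(CC(=O)N3CCN(C(C)=O)CC3)c2)c(=O)nc1SCc1ccc(F)cc1` is the next member of the series. It differs from compound 2 by 4-acetylpiperazin-1-yl in place of morpholin-4-yl on a carbonyl carbon.

Within the data shown here, the only measured step that bears on this place is a number 1 percentage points higher from compound 1 to compound 2 (within the scatter), a change of the group on the same carbonyl carbon, and it was within the scatter. Among the measured compounds shown here, no further step on this carbonyl carbon has been measured. On that basis no step beyond the scatter is expected from compound 2 to compound 3, that is a number 1 percentage points lower from compound 2 to compound 3 (within the scatter). For compound 3 in this assay the estimate is 63%, with a range from 50% to 76%.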

Compound 3, a percentage reported as inhibition, at one concentration (the size of the read-out at that concentration, not a potency): 80%
Estimate against measurement, compound 3: 17 percentage points below; the whole stated range lies below it.
By their numbers in this assay, from the lowest: compounds 1 and 2 (each within the scatter of the next); then compound 3.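

In this assay, the group on this carbonyl carbon turns out to matter: the step with 4-acetylpiperazin-1-yl in place of morpholin-4-yl is a number 16 percentage points higher from compound 2 to compound 3 (beyond the scatter), and the step with 4-acetylpiperazin-1-yl in place of methylamino is a number 17 percentage points higher from compound 1 to compound 3 (beyond the scatter), whereas the earlier step was a number 1 percentage points higher from compound 1 to compound 2 (within the scatter). Compound 1 and compound 2 alone gave no sign that this place could separate compounds, and compound 3 shows that a group with more heavy atoms is accepted here without loss of inhibition. Nothing available explains the rise.

Open, as far as these compounds go, is which part of the 4-acetylpiperazin-1-yl group carries the step: the acetyl or the ring itself. A piperazine with a free secondary amine, or one with a longer acyl chain such as propanoyl, would separate the two, and all these readings remain single-concentration figures, not potencies.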